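The source may report more compounds than this note shows. Statements on the series, on what has been measured and on what is new or still open speak of the compounds shown alone.

Three compounds have been measured in a functional assay on HT-1080 cells (Homo sapiens) for antiproliferative activity, read by MTT assay, with a stated time of 72 h; a lower number here means a stronger inhibitor, a higher number a weaker inhibitor:

- Compound 1 `COc1ccc(-c2sc(C(=O)O)cc2-c2cc(OC)c(OC)c(OC)c2)cc1`: 6770 nM
- Compound 2 `COc1cc(-c2cc(C(=O)O)sc2-c2cccc(Br)c2)cc(OC)c1OC`: > 100000 nM (a limit)
- Compound 3 `COc1ccc(-c2sc(C(=O)O)cc2-c2cc(OC)c(OC)c(OC)c2)cc1O`: 7510 nM

Compound 2 has no number of its own, only a limit, and (the limit of > 100000 nM in this assay, at which 1 of the 3 values shown sits). Compound 4 `COc1cc(-c2ccsc2-c2cccc(Br)c2)cc(OC)c1OC` differs from it in one place, with hydrogen in place of carboxy on an aromatic carbon.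

Among the compounds with values here, no measured step removes the carboxy, so the evidence is indirect. All three measured compounds carry that group. The measured steps change only the other aromatic group: an at least 14-fold higher number from compound 1 to compound 2 (1.16 log units; beyond the scatter) and an at least 13-fold lower number from compound 2 to compound 3 (1.12 log units; beyond the scatter) are both large, while a 1.1-fold higher number from compound 1 to compound 3 (0.05 log units; within the scatter) stays within the scatter. These steps show how far compound 2 lies from compound 1 and compound 3, but they give no size for losing the carboxy.

Since compound 2 is held at the limit > 100000 nM, a step to a measurable value can only appear as a lower number. A lower number is therefore expected in this assay, though compound 4 may also stop at the limit. The step expected is an at least 8.3-fold lower number from compound 2 to compound 4 (0.92 log units; beyond the scatter), a rough estimate with wide uncertainty. The estimate for compound 4 is 12000 nM, with an expected range of 1000 nM to 100000 nM.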

Compound 4, half-maximal inhibitory concentration: > 100000 nM
Compound 4: no number, only a limit; the forecaster's own chance of this, stated with the estimate: 25%; middle value at least 8.3-fold (0.92 log units) away from the limit.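

In this assay, compound 2 and compound 4 each give only a limit and not a number, so the step between them cannot be read: the limit of > 100000 nM in this assay, at which 2 of the 4 values shown sit.

The compounds shown leave open what replacing the carboxy with hydrogen does in a compound that gives a measurable value, such as compound 1 or compound 3.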